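Swapping Methyl for Chloro on a Highly Bound Compound

The source may report more compounds than this note shows. Statements on the series, on what has been measured and on what is new or still open speak of the compounds shown alone.

Compound 1 `Cc1ccc([C@@H](C)Oc2cc3onc(CCC(=O)O)c3cc2Cl)nc1`: 99.1%
Compound 2 `O=C(O)CCn1c(=O)oc2cc(OCC3CC3)c(Cl)cc21`: 90.2%

In an ADME assay on the whole organism (plasma, Rattus norvegicus, strain Han-Wistar) for protein binding, read by LC-MS, at a dose of 1 mg/kg by the intravenous route, compound 1 gives 99.1% and has the lower unbound fraction of the two measured compounds. Compound 2 stands nearest, with a higher unbound fraction, and that gap lies beyond the scatter. Compound 3 `C[C@@H](Oc1cc2onc(CCC(=O)O)c2cc1Cl)c1ccc(Cl)cn1` is still unmeasured. It carries chloro in place of methyl on an aromatic carbon and so has 5-chloropyridin-2-yl where compound 1 has 5-methylpyridin-2-yl. Going by the values given here, no measured pair shows this swap, so the expectation rests on compound 1 alone. In this assay the estimated change a 1.1-fold lower unbound fraction from compound 1 to compound 3 (0.05 log units; within the scatter) is none beyond the scatter. Compound 3 is expected to read 99.2% as the estimate, with 98.4% to 99.6% as its expected range.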

Compound 3, plasma protein binding: 99.7%
Compound 3: middle estimate off by 2.7-fold (0.43 log units) (unbound fraction), on the high side; measured number outside the range, above it.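

In this assay, chloro in place of methyl on this aromatic carbon, two atoms from the ring nitrogen, gives a 3.0-fold lower unbound fraction from compound 1 to compound 3 (0.48 log units; beyond the scatter). This position therefore still affects binding in a compound that is already very highly bound, even though the swap exchanges one heavy atom for one heavy atom and changes neither the count of hydrogen-bond donors and acceptors nor the net charge. No measurement shown here accounts for the step.

The compounds shown leave open how other groups at this position, such as fluoro, methoxy or nitrile, would compare with methyl and chloro. Going by these compounds alone, with only one pair showing this swap, they also leave open whether the same change would shift binding similarly on a different core.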